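Methoxy extension repeated on a second core

The source may report more compounds than this note shows. Statements on the series, on what has been measured and on what is new or still open speak of the compounds shown alone.

Compound 1 `COc1ccc(C(=O)/C=C/c2ccccc2-c2ccc(F)cc2)cc1OC` and compound 2 `COc1cc(C(=O)/C=C/c2ccccc2-c2ccc(F)cc2)cc(OC)c1OC` share one core; compound 2 carries a methoxy in place of hydrogen on an aromatic carbon. In a functional assay on MCF7 cells (Homo sapiens) for antiproliferative activity, read by sulforhodamine B assay, with a stated time of 48 h (a higher number here means a weaker inhibitor, a lower number a stronger inhibitor), compound 1 gives 7100 nM and compound 2 gives 9100 nM. The measured step is a 1.3-fold higher number from compound 1 to compound 2 (0.11 log units; within the scatter), within the scatter. Compound 3 `COc1ccc(CNC(=O)c2ccccc2-c2ccc(F)cc2)cc1OC` is built on a different core; the difference between the two cores is not broken down here. In this assay compound 3 gives only a limit of the assay, > 50000 nM. Compound 4 `COc1cc(CNC(=O)c2ccccc2-c2ccc(F)cc2)cc(OC)c1OC` carries the same change on the core of compound 3 (methoxy in place of hydrogen on an aromatic carbon), with the same surroundings as on compound 2. The step from compound 3 to compound 4 is expected to be a step that the limit leaves unreadable from compound 3 to compound 4, resting on the within-scatter step already seen. Compound 4 is expected to give 70000 nM, most likely again at the limit of > 50000 nM in this assay, at which 1 of the 3 values shown sits.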

Compound 4, half-maximal inhibitory concentration: > 50000 nM
Compound 4: no number, only a limit; the forecaster's own chance of this, stated with the estimate: 80%; the middle value is on the limit's open side.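

No step can be read from compound 3 to compound 4, since both values are limits and not numbers: the limit of > 50000 nM in this assay, at which 2 of the 4 values shown sit.

From the compounds shown here alone, whether methoxy in place of hydrogen on an aromatic carbon changes activity on the core of compound 3 remains open.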